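This account rests on a few compounds, and the source may have more. Where it says the series, first, only, none or still open, it means among the compounds named here.

Two compounds of this series carry the same diaryl urea core and differ only in the aromatic ring attached through the oxygen. Compound 1 `CCNc1cc(Oc2ccc(NC(=O)Nc3cccc(C(F)(F)F)c3)cc2)ncn1`, in an assay on isolated protein for inhibition of serine/threonine-protein kinase TNNI3K (Homo sapiens) (a lower number here means a stronger inhibitor, a higher number a weaker inhibitor), gives 25 nM. Compound 2 `CNc1nccc(Oc2ccc(NC(=O)Nc3cccc(C(F)(F)F)c3)cc2)n1` gives 50 nM in this assay. The step of a 2.0-fold higher number from compound 1 to compound 2 (0.30 log units; within the scatter) is the only measured one, and it does not rise above the scatter, so the two compounds are best read as equally strong. Compound 2 therefore has the higher of the two numbers, but the gap to compound 1 is too small to mean anything.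

Compound 3 `Cc1cc(Oc2ccc(NC(=O)Nc3cccc(C(F)(F)F)c3)cc2)ncn1` has not been measured yet. It differs from compound 2 in one place: 6-methylpyrimidin-4-yl in place of 2-(methylamino)pyrimidin-4-yl on an oxygen on an aromatic ring. Going by the values given here, the one measured step does not bear directly on this change, since both compound 1 and compound 2 keep an alkylamino group with its hydrogen-bond donor, while compound 3 has none. Among the compounds with values here, with no step showing what removing that donor does, the expectation is uncertain and leans toward a weaker inhibitor. The estimated step is a 3.0-fold higher number from compound 2 to compound 3 (0.48 log units; beyond the scatter). Compound 3 is expected to give about 150 nM in this assay, with a range from 40 nM to 600 nM.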

Compound 3, half-maximal inhibitory concentration: 160 nM
Compound 3: middle estimate off by 1.1-fold (0.03 log units), on the low side, within the range that was stated.
By their numbers in this assay, from the lowest: compounds 1 and 2 (each within the scatter of the next); then compound 3.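

In this assay, going by these compounds alone, replacing the alkylamino group with methyl gives the first change beyond the scatter: a 3.2-fold higher number from compound 2 to compound 3 (0.51 log units; beyond the scatter), and a 6.4-fold higher number from compound 1 to compound 3 (0.81 log units; beyond the scatter). The second of these steps is the simpler one to read, since methyl takes the place of ethylamino on the same aromatic carbon, while the first also moves from a 2-(methylamino)pyrimidin-4-yl to a 6-methylpyrimidin-4-yl group. So the group on this ring does affect the number, and here the loss of the amino nitrogen, with its hydrogen-bond donor, goes along with a weaker inhibitor, although no measurement shown explains why.

The compounds shown cannot separate the nitrogen from its hydrogen: a dimethylamino group would keep the nitrogen without that hydrogen, while a methoxy group would put an oxygen in its place. Also open, from the compounds shown here alone, is how far this group can change while the number stays as low as in compound 1 and compound 2, for example with a plain amine or a propylamino chain.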